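The source may report more compounds than this note shows. Statements on the series, on what has been measured and on what is new or still open speak of the compounds shown alone.

For the measured compounds named here, in a functional assay on CWR22R cells (Homo sapiens) for antiproliferative activity, with a stated time of 96 h (a higher number here means a weaker inhibitor, a lower number a stronger inhibitor), compound 1 (`Cc1cc(=O)oc2cc(OCC(=O)c3cc(C(F)(F)F)cc(C(F)(F)F)c3)ccc12`) gives 930 nM, the only actual number so far. Compound 2 (`Cc1cc(=O)oc2cc(OCC(=O)c3cccc(C(F)(F)F)c3)ccc12`) reads > 100000 nM, and that value is a limit of the assay. Compound 3 (`O=C(COc1ccc2c(C(F)(F)F)cc(=O)oc2c1)c1cc(C(F)(F)F)cc(C(F)(F)F)c1`) differs from compound 1 by trifluoromethyl in place of methyl on an aromatic carbon, opposite the ring oxygen: trifluoromethyl in place of methyl on an aromatic carbon. Going by the values given here, the only measured step, an at least 100-fold higher number from compound 1 to compound 2 (2.03 log units; beyond the scatter), is large but bears on this change only loosely. There, a trifluoromethyl group is lost elsewhere in the molecule, so the series can clearly react sharply to a single substitution, but no direction follows for this new place. No shift beyond the scatter is therefore the central expectation in this assay, with wide uncertainty on either side. The expected step is a 1.3-fold higher number from compound 1 to compound 3 (0.11 log units; within the scatter). For compound 3 the estimated value is 1200 nM, with an expected range of 200 nM to 8000 nM.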

Compound 3, half-maximal inhibitory concentration: "not active" (no number reported)
The entry for compound 3 holds no number, and the estimate cannot be compared.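

For the compounds shown here, compound 3 is entered as "not active" without a number, so no step from compound 1 to compound 3 can be read. Left open is how far trifluoromethyl in place of methyl on this aromatic carbon shifts the number in this assay, and how that entry relates to the limit reached by compound 2: the limit of > 100000 nM in this assay, at which 1 of the 3 values shown sits.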